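A few compounds are considered here, and "the series" means these few. Any claim that something is new, unique, unknown or untested is made for them only; others in the source may bear on it.

Compound 1, with the structure `COc1ccccc1NC(=O)c1ccccc1Sc1ccc([N+](=O)[O-])cc1`, was tested in an ADME assay on H9 cells (Homo sapiens) for cytotoxicity, read by MTT assay, with a stated time of 7 days (on this read-out higher numbers stand for lower toxicity in this test and lower numbers for higher toxicity in this test), and in that test compound 1 is recorded as "not determined" (no result reported), so compound 1 stands nowhere on the scale given here. The closest comparison available is compound 2, with the structure `COc1ccccc1NC(=O)c1sccc1Sc1ccc([N+](=O)[O-])cc1`, a compound of related build. In this assay compound 2 gives 472000 nM, a reading that indicates low toxicity toward these cells in this assay.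

Compound 3, with the structure `CNc1ccc(Sc2ccc([N+](=O)[O-])cc2)c(C(=O)Nc2ccccc2OC)c1`, has not yet been tested in this assay. Compared with compound 1, compound 3 carries one change: methylamino in place of hydrogen on an aromatic carbon. Among the compounds with values here, since compound 1 has no number, no step between them can be computed, and only the result of compound 3 on its own will be known. Any shift from adding a methylamino group is expected to be modest, within or close to the usual scatter, and no direction can be read from the data at hand. Compound 3 is estimated to give 300000 nM in this assay, with a plausible range from 80000 nM to 1000000 nM.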

Compound 3, half-maximal cytotoxic concentration: 302000 nM
Compound 3: middle estimate off by 1.0-fold (0.00 log units), on the low side; measured number inside the range.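

Within the data shown here, compound 1 has no number to set against compound 3, so no step between the two can be read. The compounds shown leave open whether methylamino in place of hydrogen changes the cytotoxicity reading at all, and in which direction. Nothing available here bears on the reading of compound 3.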